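The compounds below may be only part of what the source reports. "The series", "measured", "known", "first", "only" and "open" are said of these compounds alone.

Measured compounds in a functional assay on U-251 cells (Homo sapiens) for inhibition, read by MTT assay, with a stated time of 2 days; on this read-out higher numbers stand for weaker inhibition of growth and lower numbers for stronger inhibition of growth:

- compound 1 `Nc1ccccc1NC(=O)CCCNCC(=O)Nc1ccc(Cl)cc1` gives 11400 nM
- compound 2 `COc1ccc(NC(=O)CNc2ccc(C(=O)Nc3ccccc3N)cc2)cc1` gives 25500 nM
- compound 3 `COc1ccc(NC(=O)CNCCCC(=O)Nc2ccccc2N)cc1` gives 34000 nM

Compound 2 and compound 3 differ in more than one place; the difference between their two cores is not broken down here. Compound 2 and compound 3 sit within the scatter of each other, while compound 1 stands apart from both. For the measured compounds named here, the one counted change among the measured compounds is chloro in place of methoxy on an aromatic carbon, which gives a 3.0-fold lower number from compound 3 to compound 1 (0.47 log units; beyond the scatter), a modest but real gain.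

Compound 4 `Nc1ccccc1NC(=O)c1ccc(NCC(=O)Nc2ccc(Cl)cc2)cc1` is not yet measured in this assay. It differs from compound 2 by chloro in place of methoxy on an aromatic carbon, the same change as from compound 3 to compound 1, at a place described in the same words, though on the core of compound 2 rather than that of compound 3. Whether the gain carries over between the two cores cannot be checked with what has been measured, so the expectation for compound 4 is kept wide.

Compound 4 is expected to give about 9000 nM in this assay, with the likely range from 4000 nM to 25000 nM. That estimate means an expected step of a 2.8-fold lower number from compound 2 to compound 4 (0.45 log units; beyond the scatter), set beside the earlier 3.0-fold lower number from compound 3 to compound 1 (0.47 log units; beyond the scatter) and resting on it.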

Compound 4, concentration for 50% growth inhibition: 9400 nM
The estimate for compound 4 lay 1.0-fold (0.02 log units) below the measured number, and the stated range covers the measured number.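

In this assay, chloro in place of methoxy on an aromatic carbon gives a 2.7-fold lower number from compound 2 to compound 4 (0.43 log units; beyond the scatter), a modest step on the core of compound 2. Set beside the earlier step, the change carries over between the two cores, and the two steps cannot be told apart in size: the same change on two cores in this assay, a 3.0-fold lower number (0.47 log units; beyond the scatter) from compound 3 to compound 1 and a 2.7-fold lower number (0.43 log units; beyond the scatter) from compound 2 to compound 4, 1.1-fold (0.04 log units) apart, within the scatter of two such steps This rests on only two matched pairs, one read-out and one position, so it supports a transfer between these two cores but sets no rule for other cores or other changes, and it gives no reason for the gain.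

The compounds shown hold only 4-methoxyphenyl and 4-chlorophenyl at this place, so it remains open what a fluoro, a trifluoromethyl, a nitrile or an unsubstituted phenyl group would give on either core. As far as these compounds go, all four compounds also keep the same aminophenyl amide, so it likewise remains open what a carboxylic acid or a hydroxamic acid in its place would give, and whether the chloro-for-methoxy step would hold there.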